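The source may hold more compounds than are shown below. What is called first, only, known or untested is meant among the compounds shown, and "the series" means these compounds.

Of the compounds shown here, three have been measured in a functional assay on PC-12 cells (Rattus norvegicus) for cytotoxicity, read by MTT assay, with stated times of 2 h and 24 h, tested at 10 uM; on this read-out higher numbers stand for a stronger effect at the one concentration tested and lower numbers for a weaker effect. Compound 1 `Oc1cc(C(F)(F)F)ccc1-c1nc(-c2ccccc2O)n(-c2ccc(C(F)(F)F)cc2)n1` gives 102%. Compound 2 `COc1ccc(-n2nc(-c3ccc(C(F)(F)F)cc3O)nc2-c2ccccc2O)cc1` gives 98.9% in this assay; it differs from compound 1 in one place, (methoxy in place of trifluoromethyl on an aromatic carbon), and that change made a step of a number 3.1 percentage points lower from compound 1 to compound 2 (within the scatter). Compound 3 `Oc1cc(C(F)(F)F)ccc1-c1nc(-c2ccccc2O)n(-c2ccccc2C(F)(F)F)n1` gives 92.2%; its core differs from the core of compound 1 by 2-(trifluoromethyl)phenyl in place of 4-(trifluoromethyl)phenyl on an aromatic nitrogen, a step of a number 9.8 percentage points lower from compound 1 to compound 3 (within the scatter), and against compound 2 the step is a number 6.7 percentage points lower from compound 2 to compound 3 (within the scatter).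

Compound 4 `COc1ccccc1-n1nc(-c2ccc(C(F)(F)F)cc2O)nc1-c1ccccc1O` has not been measured. It differs from compound 3 by methoxy in place of trifluoromethyl on an aromatic carbon. Among the compounds with values here, this is the same kind of change as the one from compound 1 to compound 2, but not the same: there the group sits para to a large group, here it sits ortho to a large group. Within the data shown here, a small step is expected, a number 2.2 percentage points lower from compound 3 to compound 4 (within the scatter), because the one measured step of this kind was a number 3.1 percentage points lower from compound 1 to compound 2 (within the scatter). Compound 4 is therefore estimated at 90%, between 78% and 102%.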

Compound 4, a percentage reported as activity, at one concentration (the size of the read-out at that concentration, not a potency): 96.2%
Compound 4: the middle estimate sits 6.2 percentage points below what was measured; the measured number falls inside the stated range.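

In this assay, putting methoxy in place of trifluoromethyl on the 2-(trifluoromethyl)phenyl group gives a number 4 percentage points higher from compound 3 to compound 4 (within the scatter), and the other two comparisons give a number 2.7 percentage points lower from compound 2 to compound 4 (within the scatter) and a number 5.8 percentage points lower from compound 1 to compound 4 (within the scatter). Set beside the earlier case, the change gives no measurable difference between the two cores: the same change on two cores in this assay, a number 3.1 percentage points lower (within the scatter) from compound 1 to compound 2 and a number 4 percentage points higher (within the scatter) from compound 3 to compound 4, 7.1 percentage points apart, within the scatter of two such steps. Within the data shown here, this shows only that the swap made no step beyond the scatter on either core; two pairs do not show a real effect in either direction, nor that the step would stay this small on other cores.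

The compounds shown leave open what an amine, a carboxylic acid or a longer chain in that place would do to this read-out. They also leave open whether any change on this series can move it beyond the scatter.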